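Removing the Methyl Group from Compound 3

A few compounds are considered here, and "the series" means these few. Any claim that something is new, unique, unknown or untested is made for them only; others in the source may bear on it.

In an ADME assay on CHO cells (Cricetulus griseus) for cytotoxicity, read by MTT assay, with a stated time of 24 h (on this read-out higher numbers stand for lower toxicity in this test and lower numbers for higher toxicity in this test), compound 1 (`CC1Cn2c(nc([N+](=O)[O-])c2Br)O1`) gives 9190 nM. Compound 2 (`CC1Cn2c(nc([N+](=O)[O-])c2-c2ccc(Cl)cc2)O1`) gives > 250000 nM, which is a limit of the assay and not a number. Compound 3 (`Cc1ccc(-c2c([N+](=O)[O-])nc3n2CC(C)O3)cc1`) gives > 250000 nM, which is also only a limit. The data therefore show (the limit of > 250000 nM in this assay, at which 2 of the 3 values shown sit), and compound 3 has no exact position on the scale.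

Compound 4 (`CC1Cn2c(nc([N+](=O)[O-])c2-c2ccccc2)O1`) differs from compound 3 by hydrogen in place of methyl on an aromatic carbon, with hydrogen in place of methyl on an aromatic carbon, para to a large group. The closest measured change is a step that the two limits leave unreadable from compound 2 to compound 3, where methyl takes the place of chloro on an aromatic carbon. That step gives no size to carry over, so no change beyond the scatter is expected in this assay, although this expectation rests on little evidence. The expected change is a number no higher from compound 3 to compound 4 (the limit leaves the size open). Compound 4 is estimated at 250000 nM, with an expected range of 80000 nM to 500000 nM, and the assay may well report only a limit again.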

Compound 4, half-maximal cytotoxic concentration: > 500000 nM
Compound 4 gave a limit, no number; the forecaster's own chance of this, stated with the estimate: 75%; at least 2.0-fold (0.30 log units) between middle value and limit.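

Taking the methyl away from the aromatic carbon para to a large group does not bring a readable number, and compound 4 again sits at a limit of the assay: the limit of > 500000 nM in this assay, at which 1 of the 4 values shown sits. The steps among compound 2, compound 3 and compound 4 therefore cannot be read, but a phenyl with neither chloro nor methyl on it is enough to stay at a limit in this assay. Going by these compounds alone, the one step that can be read is an at least 54-fold higher number from compound 1 to compound 4 (1.73 log units; beyond the scatter), with phenyl in place of bromo on an aromatic carbon.

Going by these compounds, how far compound 2, compound 3 and compound 4 truly lie from one another stays open, since only limits are available for them. Also open, on these data alone, is whether an amine or a carboxylic acid on the same aromatic carbon would bring the number down to a readable value.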